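Caco-2 notes: bromo to trifluoromethyl on the aryl group

A few compounds are considered here, and "the series" means these few. Any claim that something is new, unique, unknown or untested is made for them only; others in the source may bear on it.

Measured so far:
compound 1 `CCCS(=O)(=O)Nc1ccc(F)c(C(=O)Nc2cnc3[nH]c(-c4ccccc4)cc3c2)c1F` — 5.6 10^-6 cm/s
compound 2 `CCCS(=O)(=O)Nc1ccc(F)c(C(=O)Nc2cnc3[nH]c(-c4ccc(Br)cc4)nc3c2)c1F` — 1.3 10^-6 cm/s

In an ADME assay on Caco-2 cells (Homo sapiens) for permeability, in the apical to basolateral direction (a higher number here means that the compound crosses the layer faster, a lower number that the compound crosses the layer more slowly), compound 1 gives 5.6 10^-6 cm/s. In this assay compound 2 gives 1.3 10^-6 cm/s, the lowest of the two numbers; the gap to compound 1 lies beyond the scatter. Among the compounds with values here, compound 1 and compound 2 differ in more than one place, so no single step between them is available, and only their two values can be compared.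

Compound 3 `CCCS(=O)(=O)Nc1ccc(F)c(C(=O)Nc2cnc3[nH]c(-c4ccc(C(F)(F)F)cc4)nc3c2)c1F` is not yet measured. It differs from compound 2 in one place: trifluoromethyl in place of bromo on an aromatic carbon. Within the data shown here, no step between measured compounds covers this change. The expectation is a step from compound 2 to compound 3 of a 1.2-fold higher number from compound 2 to compound 3 (0.06 log units; within the scatter), that is, no change beyond the scatter in either direction. Compound 3 is therefore expected to give about 1.5 10^-6 cm/s in this assay, with a range from 0.6 10^-6 cm/s to 4 10^-6 cm/s.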

Compound 3, apparent permeability: 1 10^-6 cm/s
Beside the measured number, compound 3's estimate is 1.5-fold (0.18 log units) above it, and the stated range covers the measured number.
By their numbers in this assay, from the lowest: compounds 3 and 2 (each within the scatter of the next); then compound 1.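

In this assay, trifluoromethyl in place of bromo on this aromatic carbon, para to a large group, gives a 1.3-fold lower number from compound 2 to compound 3 (0.11 log units; within the scatter). At this position, then, a group of 4 heavy atoms and a group of 1 heavy atom, neither with hydrogen-bond donors or acceptors, cannot be told apart in this read-out, and compound 2 and compound 3 stand together within the scatter. Nothing available bears on the reason for this result.

As far as these compounds go, whether an amine, a carboxylic acid or a longer alkyl chain on the same aromatic carbon would stay level with compound 2 and compound 3 remains open. Also open is which of the several differences between compound 1 and compound 2 accounts for the gap between their values.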